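Removing a methyl from an aryl ether: expected effect on growth inhibition

A few compounds are considered here, and "the series" means these few. Any claim that something is new, unique, unknown or untested is made for them only; others in the source may bear on it.

Compound 1 `Cc1cc(O)cc(-c2nn(CC#N)cc2-c2ccnc(-c3ccc(Oc4ccccc4)cc3)c2)c1` and compound 2 `COc1cc(C)cc(-c2nn(CC#N)cc2-c2ccnc(-c3ccc(N(C)C)cc3)c2)c1` were tested in a functional assay on NCI/ADR-RES cells (Homo sapiens) for inhibition, read by sulforhodamine B assay, with a stated time of 48 h; on this read-out higher numbers stand for weaker inhibition of growth and lower numbers for stronger inhibition of growth. Compound 1 gives 4560 nM, while compound 2 gives 655 nM, the lower of the two numbers; the gap between them lies beyond the usual scatter. Compound 3 `Cc1cc(O)cc(-c2nn(CC#N)cc2-c2ccnc(-c3ccc(N(C)C)cc3)c2)c1` differs from compound 2 by hydrogen in place of methyl on an oxygen on an aromatic ring. Among the measured compounds shown here, no measured pair shows this change alone, so its effect is open. Compound 3 is expected to give 1200 nM, within 400 nM to 4000 nM. The estimated step of a 1.8-fold higher number from compound 2 to compound 3 (0.26 log units; within the scatter) is a modest weakening, not clearly beyond the scatter.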

Compound 3, concentration for total growth inhibition: 7930 nM
For compound 3 the middle estimate is 6.6-fold (0.82 log units) below the measured one; measured number outside the range, above it.
By their numbers in this assay, from the lowest: compound 2; then compounds 1 and 3 (each within the scatter of the next).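

Hydrogen in place of methyl on this oxygen on an aromatic ring gives a 12-fold higher number from compound 2 to compound 3 (1.08 log units; beyond the scatter) in this assay and so shows that, with dimethylamino on the far ring, this methyl matters strongly for growth inhibition. With the hydroxy kept, dimethylamino in place of phenoxy gives a 1.7-fold higher number from compound 1 to compound 3 (0.24 log units; within the scatter) and so leaves the two groups indistinguishable here.

On these data alone, whether ethoxy or an amine in place of methoxy would hold the lower number, and whether phenoxy would behave like dimethylamino alongside methoxy, remains open. Nothing given here offers a reason for the large step.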